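A few compounds are considered here, and "the series" means these few. Any claim that something is new, unique, unknown or untested is made for them only; others in the source may bear on it.

Measured in a functional assay on MCF-10A cells (Homo sapiens) for antiproliferative activity, with a stated time of 48 h; on this read-out higher numbers stand for an effect only at larger amounts of compound and lower numbers for an effect already at smaller amounts:
- compound 1, `COc1ccc2nc(C)cc(NCc3ccc(C)cc3)c2c1`: 22400 nM
- compound 2, `COc1ccc2nc(C)cc(NCc3ccc(C(C)(C)C)cc3)c2c1`: 7000 nM

Compound 2 stands lowest of the two numbers in this assay; its nearest neighbour is compound 1, separated by a 3.2-fold lower number from compound 1 to compound 2 (0.51 log units; beyond the scatter), a step described as modest but beyond the scatter.

The next compound is compound 3, `COc1ccc2nc(C)cc(NCc3ccc(C(F)(F)F)cc3)c2c1`. Relative to compound 2 the change is trifluoromethyl in place of tert-butyl on an aromatic carbon. Among the compounds with values here, only one measured step bears on this position: a 3.2-fold lower number from compound 1 to compound 2 (0.51 log units; beyond the scatter) shows that a larger group in place of methyl at this aromatic carbon lowered the number. Within the data shown here, no measured pair compares tert-butyl with trifluoromethyl, so the direction of the new step is not fixed by the data. The expectation for compound 3 is therefore a small change, most likely a number somewhat higher than that of compound 2, within or just beyond the scatter, as a 1.4-fold higher number from compound 2 to compound 3 (0.15 log units; within the scatter). The estimate for compound 3 in this assay is 10000 nM, with a range from 4000 nM to 25000 nM.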

Compound 3, half-maximal effective concentration: 7600 nM
For compound 3 the middle estimate is 1.3-fold (0.12 log units) above the measured one; measured number inside the range.
By their numbers in this assay, from the lowest: compounds 2 and 3 (each within the scatter of the next); then compound 1.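

In this assay, tert-butyl and trifluoromethyl at this aromatic carbon are not told apart, with a 1.1-fold higher number from compound 2 to compound 3 (0.04 log units; within the scatter) as the whole difference, even though the two groups share only their count of 4 heavy atoms and differ in their elements. Trifluoromethyl in place of methyl gives a 2.9-fold lower number from compound 1 to compound 3 (0.47 log units; beyond the scatter) in this series, so the lower number seen with tert-butyl is not confined to that one group. No measurement shown gives a reason for either step.

Still open, going by these compounds, is whether a group of another kind at this carbon, such as an amine, a carboxylic acid or a longer chain, would keep, lose or go beyond this level. Also open, on these data alone, is how the unsubstituted carbon compares with methyl.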